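The source may hold more compounds than are shown below. What is called first, only, known or untested is meant among the compounds shown, and "the series" means these compounds.

Compound 1 `C[C@H](c1ccc(C(=O)NCCC(=O)O)cc1)N1C(=O)C(c2ccc(F)cc2)=N[C@]12CC[C@@H](C(C)(C)C)CC2` is one of two compounds in this set with a result in an assay on CHO cells for displacement of a labelled ligand from Glucagon receptor (Homo sapiens), read by scintillation counting, with a stated time of 60 min; a lower number here means a stronger inhibitor, a higher number a weaker inhibitor. In this assay compound 1 gives 85 nM, the higher of the two numbers. The other compound, compound 2 `CC(C)(C)CC[C@H](c1ccc(C(=O)NCc2nn[nH]n2)cc1)N1C(=O)C(c2ccc(C(F)(F)F)cc2)=N[C@]12CC[C@@H](C(C)(C)C)CC2`, gives 7 nM in this assay, a lower number that lies beyond the usual scatter; since compound 2 differs from compound 1 in several places at once, these two values show only that the series spans a wide range.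

Compound 3 `C[C@H](c1ccc(C(=O)NCCC(=O)O)cc1)N1C(=O)C(c2cccc(Cl)c2F)=N[C@]12CC[C@@H](C(C)(C)C)CC2` has not yet been measured. It differs from compound 1 in one place: 3-chloro-2-fluorophenyl in place of 4-fluorophenyl on a carbon with a double bond to nitrogen. Within the data shown here, no single-point step of this kind exists among the measured compounds, so the size of its effect in this assay is open. A change limited to halogens on one aromatic ring is expected to give a small step, if any, towards a lower number, likely within the scatter. Compound 3 is therefore estimated at 60 nM in this assay, with a range from 20 nM to 200 nM, which corresponds to an expected step of a 1.4-fold lower number from compound 1 to compound 3 (0.15 log units; within the scatter).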

Compound 3, half-maximal inhibitory concentration: 620 nM
Compound 3: middle estimate off by 10-fold (1.01 log units), on the low side; the whole stated range lies below it.
By their numbers in this assay, from the lowest: compound 2; then compound 1; then compound 3.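

Changing the halogens on this phenyl ring is not a minor edit in this assay: 3-chloro-2-fluorophenyl in place of 4-fluorophenyl gives a 7.3-fold higher number from compound 1 to compound 3 (0.86 log units; beyond the scatter), with the rest of compound 1 unchanged. Among these compounds, this is the first comparison in the set that isolates a single place, and it shows that the aromatic group on the carbon with a double bond to nitrogen strongly affects the result, even though the group gains only one heavy atom and its counts of hydrogen-bond donors and acceptors stay the same. No measurement here accounts for the higher number, so the step remains an observation without a known cause.

The compounds shown leave open whether the step comes from adding the chlorine, from moving the fluorine, or from the two together; 3-chlorophenyl and 2-fluorophenyl on the core of compound 1 would separate these possibilities. From the compounds shown here alone, it is also open whether the same change would have a similar effect with the other parts of compound 2 in place.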